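A few compounds are considered here, and "the series" means these few. Any claim that something is new, unique, unknown or untested is made for them only; others in the source may bear on it.

The series shares one core, seen in compound 1 `O=C1O[C@H]([C@@H](O)Cn2cc(CNS(=O)(=O)c3ccc(F)cc3)nn2)C(OCc2ccccc2)=C1OCc1ccccc1` and compound 2 `O=C1O[C@H]([C@@H](O)Cn2cc(CCCCl)nn2)C(OCc2ccccc2)=C1OCc1ccccc1`. In a functional assay on HepG2 cells (Homo sapiens) for antiproliferative activity, read by MTT assay, with a stated time of 72 h (on this read-out higher numbers stand for weaker inhibition and lower numbers for stronger inhibition), compound 1 gives 18300 nM, and compound 2 gives 35000 nM. Going by the values given here, on these two numbers compound 2 stands at the higher end, with compound 1 as its only neighbour, and the step between them is a 1.9-fold higher number from compound 1 to compound 2 (0.28 log units; within the scatter), so the two cannot be set apart. Compound 3 `O=C1O[C@H]([C@@H](O)Cn2cc(-c3ccc(Br)cc3)nn2)C(OCc2ccccc2)=C1OCc1ccccc1` is not yet measured. Its change from compound 2 is 4-bromophenyl in place of 3-chloropropyl on an aromatic carbon. Among the compounds with values here, no measured step touches this position: the single step available, from compound 1 to compound 2, alters the group on the saturated chain carbon bound to the aromatic carbon, not the aromatic carbon of the five-membered aromatic ring with 3 nitrogen itself, and it stayed within the scatter. This gives no footing for a large step in either direction in this assay, so a step of about a 1.4-fold lower number from compound 2 to compound 3 (0.15 log units; within the scatter) is expected, inside the scatter. Compound 3 is accordingly estimated at 25000 nM, with a range from 9000 nM to 70000 nM.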

Compound 3, half-maximal inhibitory concentration: 5070 nM
Estimate against measurement, compound 3: 4.9-fold (0.69 log units) above; the whole stated range lies above it.
By their numbers in this assay, from the lowest: compound 3; then compounds 1 and 2 (each within the scatter of the next).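

In this assay, going by these compounds alone, the aromatic carbon of the five-membered aromatic ring with 3 nitrogen responds to a change of group: 4-bromophenyl in place of 3-chloropropyl gives (a 6.9-fold lower number from compound 2 to compound 3 (0.84 log units; beyond the scatter)), the first step to lie beyond the scatter, though still a modest one. The same group in place of (((4-fluorophenyl)sulfonyl)amino)methyl gives (a 3.6-fold lower number from compound 1 to compound 3 (0.56 log units; beyond the scatter)), also modest and beyond the scatter, so compound 3 separates from both earlier compounds, which themselves cannot be told apart. No supporting measurement on this result is available, and the reason for the shift remains unexplained.

The compounds shown do not tell whether the lower number goes with the six-membered aromatic ring or with its bromine, a question that plain phenyl, 4-fluorophenyl and 4-methoxyphenyl would address. Going by these compounds, it also remains open how a benzyl group, with one carbon set into the link, or a basic group such as an aminomethyl would read at this position, and whether the step holds on a different core or in other cells.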